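A Methoxy Group Added to the Phenyl Ring of Compound 1

The source may hold more compounds than are shown below. What is called first, only, known or untested is meant among the compounds shown, and "the series" means these compounds.

Compound 1, `CN1C[C@@H](c2ccccc2)[C@@]2(Cc3ccccc3C2=O)[C@@]12C(=O)Nc1ccccc12`: 42.5%
Compound 2, `CN1C(=O)[C@@]2(c3ccccc31)N(C)C[C@@H](c1ccc(Cl)cc1)[C@@]21Cc2ccccc2C1=O`: 9.4%
Compound 3, `Cc1ccc([C@@H]2CN(C)[C@]3(C(=O)N(C)c4ccccc43)[C@]23Cc2ccccc2C3=O)cc1`: 6.4%

Three compounds sharing one core were tested in a functional assay on the whole organism (strain Wister albino) for inhibition, with Rattus norvegicus as the target, read by paw edema, with stated times of 1 h and 3 h, at a dose of 50 mg/kg by the intraperitoneal route; a lower number here means less inhibition, a higher number more inhibition at the dose given (going by the name of the read-out). Compound 1 stands highest of the three; compound 2 lies well below it, and compound 3 lies lower still, both gaps beyond the usual scatter. Going by the values given here, compound 2 and compound 3 each differ from compound 1 in two places at once, and the only single change among the measured compounds is a number 3 percentage points lower from compound 2 to compound 3 (within the scatter), a difference too small to count as a real change.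

Compound 4, `COc1ccc([C@@H]2CN(C)[C@]3(C(=O)Nc4ccccc43)[C@]23Cc2ccccc2C3=O)cc1`, has not yet been measured. It differs from compound 1 by methoxy in place of hydrogen on an aromatic carbon. Among the compounds with values here, no measured pair shows this change on its own. Within the data shown here, the pair of compound 2 and compound 3 shows only that exchanging one small group on that ring for another left the read-out where it was. Both of those compounds also carry a methyl on the amide nitrogen, so their low numbers cannot be tied to the ring group alone. With nothing firm to anchor the step, the expectation for compound 4 is a value near compound 1 or somewhat lower, a number 10.5 percentage points lower from compound 1 to compound 4 (beyond the scatter), estimated at 32% with a likely range from 12% to 50%.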

Compound 4, a percentage reported as inhibition, in the whole organism at one dose (the size of the read-out at that dose, not a potency): 20.5%
Estimate against measurement, compound 4: 11.5 percentage points above; measured number inside the range.
By their numbers in this assay, from the lowest: compounds 3 and 2 (each within the scatter of the next); then compound 4; then compound 1.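

In this assay, going by these compounds alone, going from phenyl to 4-methoxyphenyl is the first single change in this set that moves the read-out beyond the scatter, with a number 22 percentage points lower from compound 1 to compound 4 (beyond the scatter) at the dose given. The only earlier single change at this place, para to a large group, swapped chloro for methyl on compounds that also carry a methyl on the amide nitrogen, and it stayed within the scatter; here the amide hydrogen is kept, so the drop belongs to the new group on the ring alone, and this position is shown not to be indifferent to what sits on it. Nothing measured here says why adding methoxy lowers the inhibition.

As far as these compounds go, whether any group at this place would lower the number, or methoxy in particular, stays open, and a hydroxy group, an amine or a longer chain such as ethoxy would each help to separate the two. Also open, from the compounds shown here alone, is how chloro or methyl at this place would behave with the amide hydrogen in place, which would show how much of the low numbers of compound 2 and compound 3 comes from the ring group.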